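This account rests on a few compounds, and the source may have more. Where it says the series, first, only, none or still open, it means among the compounds named here.

Compound 1 `COc1ccc2c(c1)C/C(=C\c1cc(-c3cc(OC)c(OC)c(OC)c3)n[nH]1)C2=O` and compound 2 `COc1cc(-c2cc(/C=C3\Cc4ccccc4C3=O)[nH]n2)cc(OC)c1OC` share a core in which a fused two-ring system carries the olefinic link to the pyrazole. In a functional assay on MCF7 cells (Homo sapiens) for inhibition, read by MTT assay, with a stated time of 48 h (a higher number here means a weaker inhibitor, a lower number a stronger inhibitor), compound 1 gives 2100 nM, while compound 2 gives 4800 nM. The single difference between them is hydrogen in place of methoxy on an aromatic carbon, and the step of a 2.3-fold higher number from compound 1 to compound 2 (0.36 log units; beyond the scatter) shows that removing this methoxy costs some potency.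

Compound 3 `COc1cc(C(=O)/C=C/c2cc(-c3cc(OC)c(OC)c(OC)c3)n[nH]2)cc(OC)c1OC` is built on a different core, and how the two cores differ is not broken down here. In this assay compound 3 gives 430 nM, the lowest number of the three measured compounds, with compound 1 next and compound 2 furthest away.

Compound 4 `COc1ccc(-c2cc(/C=C/C(=O)c3cc(OC)c(OC)c(OC)c3)[nH]n2)cc1OC` is not yet measured. It is related to compound 3 by hydrogen in place of methoxy on an aromatic carbon. Within the data shown here, this is the same kind of change as the one from compound 1 to compound 2, but the surroundings differ: in compound 1 the methoxy that leaves sits on a ring that is part of a fused or bridged system of two rings, meta to a fused ring and para to a fused ring, whereas in compound 3 it sits on a ring of carbon only, ortho to a methoxy group, meta to a large group and meta to a methoxy group.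

Because compound 3 gives 430 nM and the earlier step was a 2.3-fold higher number from compound 1 to compound 2 (0.36 log units; beyond the scatter), a comparable loss is expected for compound 4, namely a 2.3-fold higher number from compound 3 to compound 4 (0.37 log units; beyond the scatter). Compound 4 is therefore estimated at 1000 nM, with a range from 400 nM to 2600 nM.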

Compound 4, half-maximal inhibitory concentration: 1100 nM
Beside the measured number, compound 4's estimate is 1.1-fold (0.04 log units) below it; the range from low to high includes it.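

In this assay, replacing methoxy with hydrogen on the core of compound 3 gives a 2.6-fold higher number from compound 3 to compound 4 (0.41 log units; beyond the scatter), a modest loss of the same direction as the one already seen on the core of compound 1. Within this small series, the cost of removing this methoxy group therefore carries from one core to the other, and the two steps do not differ in size: the same change on two cores in this assay, a 2.3-fold higher number (0.36 log units; beyond the scatter) from compound 1 to compound 2 and a 2.6-fold higher number (0.41 log units; beyond the scatter) from compound 3 to compound 4, 1.1-fold (0.05 log units) apart, within the scatter of two such steps This agreement rests on just one pair of compounds per core, with the methoxy leaving from different surroundings in each, so it shows neither that the step would hold on any further core nor why removing the group weakens inhibition in these cells.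

The compounds shown leave open what other groups would do at these places, for instance whether a hydroxyl group, a fluorine atom, an amine or a longer chain such as ethoxy would keep the number close to that of the methoxy compounds or move it further away. They also leave open whether the same step would appear in cell lines other than the one used in this assay, since every number here comes from that single assay.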